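Replacing the Nitro Group of Compound 2 with Hydrogen

The source may report more compounds than this note shows. Statements on the series, on what has been measured and on what is new or still open speak of the compounds shown alone.

Measured in an ADME assay on L6 cells (Rattus norvegicus) for cytotoxicity; a higher number here means a weaker inhibitor, a lower number a stronger inhibitor:
Compound 1 (`c1ccc(Oc2ccc(-c3cc(N4CCNCC4)[nH]n3)cc2)cc1`): 18000 nM
Compound 2 (`CSC(=CC(=O)c1ccc(Oc2ccc([N+](=O)[O-])cc2)cc1)SC`): 156000 nM

Compound 2 has the higher of the two numbers, so it is the weaker inhibitor in this cell test. Compound 1 lies well below it, and that gap is beyond the usual scatter. Compound 3 (`CSC(=CC(=O)c1ccc(Oc2ccccc2)cc1)SC`) has not yet been measured and differs from compound 2 in one place (hydrogen in place of nitro on an aromatic carbon): hydrogen in place of nitro on an aromatic carbon. Going by the values given here, no measured pair shows this change on its own, so any forecast is loose. Among the compounds with values here, compound 1, the only measured compound without a nitro group, gives 18000 nM in this assay and also differs elsewhere. A modest step towards a lower number is expected, estimated as a 2.6-fold lower number from compound 2 to compound 3 (0.41 log units; beyond the scatter) overall. Compound 3 is expected at 60000 nM (estimated range 18000 nM to 180000 nM).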

Compound 3, half-maximal inhibitory concentration: 34500 nM
Beside the measured number, compound 3's estimate is 1.7-fold (0.24 log units) above it, and the stated range covers the measured number.
By their numbers in this assay, from the lowest: compounds 1 and 3 (each within the scatter of the next); then compound 2.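

In this assay, going by these compounds alone, the swap of nitro for hydrogen on this aromatic carbon gives a 4.5-fold lower number from compound 2 to compound 3 (0.66 log units; beyond the scatter) and is the first view of this change on its own, with the rest of the molecule held the same. The position is therefore not silent: what sits on this ring carbon changes the number, and the form with hydrogen is the stronger inhibitor of the pair in this cell test. Nothing available here accounts for why the number moves.

The compounds shown leave open whether another group on this carbon, such as an amine, a methoxy group or a carboxylic acid, would fall nearer the nitro compound or the hydrogen compound. They also leave open whether the same swap would give a step of similar size on a different core.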